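This account rests on a few compounds, and the source may have more. Where it says the series, first, only, none or still open, it means among the compounds named here.

Measured so far: compound 1 `N[C@H](COc1ccc(Cl)cc1)c1ccccc1` with 3020 nM in an assay on isolated protein for inhibition of sodium channel protein type 4 subunit alpha (Homo sapiens) (on this read-out higher numbers stand for an effect only at larger amounts of compound and lower numbers for an effect already at smaller amounts), and compound 2 `N[C@@H](COc1ccccc1)c1ccccc1` with 3980 nM in this assay.

Compound 2 and compound 1 stand close together: the gap between them lies within the scatter of repeated measurements, so the two numbers cannot be told apart with confidence. Compound 3 `N[C@H](COc1ccccc1)c1ccccc1` has not been measured. It differs from compound 2 as follows: the two compounds have the same atoms and bonds and differ only in configuration as drawn: 1 of 1 stereo elements differ; a stereocentre at a saturated chain carbon is drawn R in compound 2 and S in compound 3. Among the measured compounds shown here, no measured pair in this set shows what such a change in configuration at the stereocentre does to the number, so the expectation rests on the two measured values alone. Because compound 2 gives 3980 nM, compound 3 is expected to land in the same region; the step of a 1.1-fold lower number from compound 2 to compound 3 (0.06 log units; within the scatter) is expected to be small, with no direction beyond the scatter claimed. The estimate for compound 3 is 3500 nM, within a range from 1000 nM to 12000 nM.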

Compound 3, half-maximal effective concentration: 15800 nM
Beside the measured number, compound 3's estimate is 4.5-fold (0.65 log units) below it, and the stated range ends below it.
By their numbers in this assay, from the lowest: compounds 1 and 2 (each within the scatter of the next); then compound 3.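

The stereocentre at the saturated chain carbon turns out to matter in this assay: going from R to S gives a 4.0-fold higher number from compound 2 to compound 3 (0.60 log units; beyond the scatter). That step can be set on the stereocentre alone because nothing else separates the two compounds: the fact that compounds 2 and 3 differ only in the configuration as drawn. With the stereocentre drawn S, the aromatic substituent also registers, as hydrogen in place of chloro on an aromatic carbon gives a 5.2-fold higher number from compound 1 to compound 3 (0.72 log units; beyond the scatter).

The compounds shown leave open whether chloro has a comparable effect with the stereocentre drawn R, and so whether the two changes act independently. Also open, from the compounds shown here alone, is what a fluoro or methoxy group on that aromatic carbon, or an acetyl group on the amine, would do to the number.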